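From nitro to cyano: expected step for compound 4

A few compounds are considered here, and "the series" means these few. Any claim that something is new, unique, unknown or untested is made for them only; others in the source may bear on it.

compound 1 `CN1C/C(=C\c2ccncc2)C(=O)/C(=C/c2ccc(C#N)cc2)C1` gives 18500 nM
compound 2 `Cc1ccc(S(=O)(=O)N2C/C(=C\c3cccnc3)C(=O)/C(=C/c3ccccc3F)C2)cc1` gives 10300 nM
compound 3 `O=C1/C(=C/c2cccnc2)CN(S(=O)(=O)c2ccc([N+](=O)[O-])cc2)C/C1=C\c1ccccc1F` gives > 20000 nM as a limit, not a number

All three readings come from a functional assay on SMMC-7721 cells (Homo sapiens) for cytotoxicity, read by MTT assay, with a stated time of 24 h (a higher number here means a weaker inhibitor, a lower number a stronger inhibitor), and make up the whole of the measured series. Compound 3 stands at the limit of > 20000 nM in this assay, at which 1 of the 3 values shown sits, and so has a limit rather than a number of its own.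

Compound 4 `N#Cc1ccc(S(=O)(=O)N2C/C(=C\c3cccnc3)C(=O)/C(=C/c3ccccc3F)C2)cc1` comes from compound 3 by a single change, cyano in place of nitro on an aromatic carbon, para to a large group: cyano in place of nitro on an aromatic carbon is the whole of the difference.

Among the compounds with values here, the one measured step at that place is an at least 1.9-fold higher number from compound 2 to compound 3 (0.28 log units; that floor lies within the scatter) with nitro in place of methyl on an aromatic carbon. Within the data shown here, no measured step brings cyano into that place. With compound 2 at 10300 nM and that step not shown to exceed the scatter, compound 4 is expected to sit in the same upper part of the range. No step beyond the scatter is expected in this assay and the estimated at least 1.5-fold lower number from compound 3 to compound 4 (0.18 log units; that floor lies within the scatter) stays inside it. The estimate for compound 4 is 13000 nM and is expected to fall between 6500 nM and 20000 nM in repeat measurements.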

Compound 4, half-maximal inhibitory concentration: 15400 nM
Estimate against measurement, compound 4: 1.2-fold (0.07 log units) below, within the range that was stated.
By their numbers in this assay, from the lowest: compounds 2, 4 and 1 (each within the scatter of the next). At a limit, above all of these: compound 3.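

In this assay, cyano on the aromatic carbon, para to a large group, can now be set against methyl at the same place: a 1.5-fold higher number from compound 2 to compound 4 (0.17 log units; within the scatter), so this exchange does not separate the two compounds. Against nitro, the series gives an at least 1.2-fold lower number from compound 3 to compound 4 (0.11 log units; that floor lies within the scatter), and this floor does not show that cyano and nitro differ at this position. Compound 3 has a limit and not a number, so the true size of this step stays unknown and only a floor can be given: the limit of > 20000 nM in this assay, at which 1 of the 4 values shown sits.

Methyl, nitro and cyano are the only groups shown at this place, and no step among them is shown to exceed the scatter, so it remains open whether this position can move the reading in this assay at all. An amine or a carboxylic acid on the same aromatic carbon would test that, and compound 1, which differs from compound 4 in more than one place, gives no guide to either.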